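The compounds below may be only part of what the source reports. "The series", "measured", "known", "first", "only" and "open" are said of these compounds alone.

The four compounds here rest on two cores. Compound 1 `COc1ccc(OS(=O)(=O)c2ccc(N3CCN(C)C3=O)cc2)cc1` and compound 2 `CN1CCN(c2ccc(S(=O)(=O)Oc3ccc(F)cc3)cc2)C1=O` share one; compound 3 `CCCN1CCN(c2ccc(S(=O)(=O)Oc3cccc(OC)c3)cc2)C1=O` and compound 4 `CCCN1CCN(c2ccc(S(=O)(=O)Oc3cccc(F)c3)cc2)C1=O` share the other. How the two cores differ is not broken down here. All of them are tested in a functional assay on M21 cells (Homo sapiens) for antiproliferative activity, read by sulforhodamine B assay, with a stated time of 48 h; a higher number here means a weaker inhibitor, a lower number a stronger inhibitor. For compound 1 the result is a limit of the assay, > 100000 nM. For compound 2 the result is likewise a limit, > 100000 nM. Compound 3 gives an actual number in this assay, 10000 nM. The change from compound 1 to compound 2 is fluoro in place of methoxy on an aromatic carbon; the step it made, a step that the two limits leave unreadable from compound 1 to compound 2, stays unreadable because both values sit at the limit of > 100000 nM in this assay, at which 2 of the 3 values shown sit. The change from compound 3 to compound 4 is fluoro in place of methoxy on an aromatic carbon, the same kind of change, though here the group stands meta to a large group where in compound 1 it stands para to a large group. With no readable step to build on, compound 4 is expected to move only modestly from compound 3, by a 2.0-fold higher number from compound 3 to compound 4 (0.30 log units; within the scatter). In this assay compound 4 is estimated at 20000 nM.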

Compound 4, half-maximal inhibitory concentration: 12000 nM
Beside the measured number, compound 4's estimate is 1.7-fold (0.22 log units) above it; the range from low to high includes it.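

On the core of compound 3, where the group stands meta to a large group, fluoro in place of methoxy gives a 1.2-fold higher number from compound 3 to compound 4 (0.08 log units; within the scatter) in this assay, so swapping these two groups makes no readable difference on this core. On the core of compound 1 the same change cannot be read, because compound 1 and compound 2 both stand at a limit of the assay rather than at a number: the limit of > 100000 nM in this assay, at which 2 of the 4 values shown sit. The series therefore offers one readable step for this change, and that step does not show whether the change behaves alike on both cores, as a second readable step to compare it with is missing.

Open, as far as these compounds go, is whether a different group in the same place on the aromatic ring, such as an amine, a carboxylic acid or a nitrile, would move the number beyond the scatter. Also open, from the compounds shown here alone, is what a longer chain on the core would do in this assay.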